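This account rests on a few compounds, and the source may have more. Where it says the series, first, only, none or still open, it means among the compounds named here.

Compounds measured so far:
compound 1 `C=C[C@](C)(O)CC[C@@]1(C)[C@H](C)C[C@H](O[C@@H]2O[C@@H](C)[C@H](O[C@@H]3O[C@H](CO)[C@@H](OC(C)=O)[C@H](O)[C@H]3O)[C@@H](O)[C@H]2O)[C@@]2(C)C(C)=CCC[C@H]12`, 305000 nM
compound 2 `CC1=CCC[C@@H]2[C@@](C)(CC/C(C)=C/CO)[C@H](C)C[C@H](O[C@@H]3O[C@@H](C)[C@H](O[C@@H]4O[C@H](CO)[C@@H](O)[C@H](O)[C@H]4O)[C@@H](O)[C@H]3O)[C@@]12C`, 325000 nM

In an ADME assay on C8166 cells (Homo sapiens) for cytotoxicity, read by MTT assay (on this read-out higher numbers stand for lower toxicity in this test and lower numbers for higher toxicity in this test), compound 1 gives 305000 nM. In this assay compound 2 gives 325000 nM, which sits alongside the number for compound 1 within the scatter, so the two compounds cannot be set apart on this read-out. Within the data shown here, compound 1 and compound 2 differ in more than one place, so no single step connects them.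

Compound 3 `CC(=O)OC[C@H]1O[C@@H](O[C@@H]2[C@@H](O)[C@@H](O)[C@H](O[C@H]3C[C@@H](C)[C@](C)(CC/C(C)=C/CO)[C@H]4CCC=C(C)[C@]34C)O[C@H]2C)[C@H](O)[C@@H](O)[C@@H]1O` has not yet been tested in this assay. It differs from compound 2 by one change: acetyl in place of hydrogen on an oxygen on a saturated carbon. Compound 1 already carries an acetoxy group on its sugar and gives a number close to that of compound 2, so the step from compound 2 to compound 3 is expected to be small and to stay within the scatter, a 1.0-fold lower number from compound 2 to compound 3 (0.02 log units; within the scatter). Compound 3 is therefore estimated at 310000 nM, in the range 150000 nM to 620000 nM.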

Compound 3, half-maximal cytotoxic concentration: 136000 nM
The estimate for compound 3 lay 2.3-fold (0.36 log units) above the measured number, outside the stated range (below it).
By their numbers in this assay, from the lowest: compound 3; then compounds 1 and 2 (each within the scatter of the next).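

In this assay the step from hydroxymethyl to acetoxymethyl gives a 2.4-fold lower number from compound 2 to compound 3 (0.38 log units; beyond the scatter), a modest change that lies beyond the scatter and points to higher toxicity in this test. Among these compounds, it is the only single-place step among the three compounds, and it shows that this oxygen on a saturated carbon is not indifferent to acetyl in place of hydrogen, which the pair of compound 1 and compound 2 could not show. Nothing measured here gives a reason for the step.

On these data alone, whether a longer chain on the same oxygen, such as butyryl, or a plain methyl ether would move the number in the same direction remains open. So does whether acetyl on another hydroxy of the sugars would give a step of similar size, since one step at one place sets no trend.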